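Swapping the aryl group on the hydrazone carbon

The source may hold more compounds than are shown below. What is called first, only, known or untested is meant among the compounds shown, and "the series" means these compounds.

Going by the values given here, compound 2 `CN(C)CCn1cnnc1-c1cc(Oc2ccc(NC(=O)N/N=C/c3cccc(Br)c3)cc2F)ccn1` stands at the higher end of the two numbers so far: in a functional assay on MKN-45 cells (Homo sapiens) for cytotoxicity, read by MTT assay, with a stated time of 72 h (a higher number here means a weaker inhibitor, a lower number a stronger inhibitor), compound 2 gives 450 nM, whereas compound 1 `CN(C)CCn1cnnc1-c1cc(Oc2ccc(NC(=O)N/N=C/c3c(Cl)cccc3Cl)cc2F)ccn1` gives 160 nM. Among the compounds with values here, the only step between them, a 2.8-fold higher number from compound 1 to compound 2 (0.45 log units; beyond the scatter), shows that exchanging the aryl group on the carbon with a double bond to nitrogen can shift the read-out by a modest amount. Compound 3 `COc1cc(/C=N/NC(=O)Nc2ccc(Oc3ccnc(-c4nncn4CCN(C)C)c3)c(F)c2)ccc1O` changes the same position again: 4-hydroxy-3-methoxyphenyl in place of 3-bromophenyl on a carbon with a double bond to nitrogen. Within the data shown here, that single earlier step is the only guide for this change, and it points to a modest move in either direction rather than to a large one, with no clear sign of which way. A number close to that of compound 2, or somewhat higher, is therefore expected for compound 3, with a 1.3-fold higher number from compound 2 to compound 3 (0.12 log units; within the scatter) as the central guess. Compound 3 is expected to give about 600 nM in this assay, within a range of 150 nM to 2500 nM.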

Compound 3, half-maximal inhibitory concentration: 3780 nM
Estimate against measurement, compound 3: 6.3-fold (0.80 log units) below, outside the stated range (above it).
By their numbers in this assay, from the lowest: compound 1; then compound 2; then compound 3.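

In this assay this position proves more sensitive than the first exchange suggested: 4-hydroxy-3-methoxyphenyl in place of 3-bromophenyl gives a far larger shift (an 8.4-fold higher number from compound 2 to compound 3 (0.92 log units; beyond the scatter)), and in place of 2,6-dichlorophenyl a larger one still (a 24-fold higher number from compound 1 to compound 3 (1.37 log units; beyond the scatter)). Among these three compounds, the two aryl groups bearing halogen atoms stand lowest, while the group with 1 hydrogen-bond donor and 2 hydrogen-bond acceptors stands highest, making compound 3 the weakest of the three, with its steps to both others beyond the scatter. Nothing available here explains the size of this shift.

Going by these compounds, the hydroxy and methoxy groups enter together in compound 3, so their separate contributions remain open. On these data alone, it also remains open how this assay would read an amine or a carboxylic acid on this aryl ring, or an unsubstituted phenyl.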